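The source may report more compounds than this note shows. Statements on the series, on what has been measured and on what is new or still open speak of the compounds shown alone.

Compound 1 `Cc1ccc(S(=O)(=O)Nc2ccc(Oc3ccccc3)cc2)cc1`: 100%; compound 2 `O=S1(=O)c2ccccc2CN1c1cccc(Oc2ccccc2)c1`: 39%; compound 3 `Cc1ccccc1Oc1cc(F)cc(N2Cc3ccccc3S2(=O)=O)c1`: 71%.

All three numbers come from a functional assay on Flp-In T-REx293 cells for antagonist activity at Free fatty acid receptor 1 (Homo sapiens), read by calcium flux; on this read-out higher numbers stand for larger maximal responses and lower numbers for smaller maximal responses. Compound 3 stands second highest of the three: compound 1 lies above it by more than the usual scatter, and compound 2 lies below it by more than the usual scatter. Compound 4 `N#Cc1ccc(Oc2cc(F)cc(N3Cc4ccccc4S3(=O)=O)c2)cc1` has not yet been measured in this assay. It differs from compound 3 in a single place: 4-cyanophenyl in place of 2-methylphenyl on an oxygen on an aromatic ring. Within the data shown here, no single-change step between measured compounds is available to show how large such an exchange tends to be, so the expectation rests on the spread of the three values alone. A small downward step is expected, one that may well stay within the scatter. Compound 4 is estimated to give 65%, with a range from 40% to 90%. This estimate corresponds to an expected step of a number 6 percentage points lower from compound 3 to compound 4 (within the scatter).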

Compound 4, largest response reached (reported as Imax), in percent of the reference or control that the assay uses: 43%
Compound 4: the middle estimate sits 22 percentage points above what was measured; measured number inside the range.
By their numbers in this assay, from the lowest: compounds 2 and 4 (each within the scatter of the next); then compound 3; then compound 1.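

Among these compounds, this is the first single-change step in the set: in this assay, putting 4-cyanophenyl in place of 2-methylphenyl on an oxygen on an aromatic ring gives a number 28 percentage points lower from compound 3 to compound 4 (beyond the scatter) for the maximal response. The group at this position therefore matters, since this exchange alone moves the number by more than the usual scatter. Nothing shown here explains the drop.

The step changes both the kind of group on the outer ring and where it sits, so 2-methylphenyl and 4-cyanophenyl alone cannot separate those two changes. Also open, as far as these compounds go, is how a carboxylic acid or an amine in place of the nitrile would read out.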